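The compounds below may be only part of what the source reports. "The series", "measured", "known", "first", "only" and "open" are said of these compounds alone.

Measured compounds:
Compound 1 `CCOC(=O)C1=Cc2ccccc2OC1(OCc1cn(-c2ccccc2)nn1)C(F)(F)F` — in a functional assay on MCF7 cells (Homo sapiens) for inhibition, read by MTT assay, with a stated time of 24 h (on this read-out lower numbers stand for stronger inhibition and higher numbers for weaker inhibition), compound 1 gives only a limit, > 150000 nM.
Compound 2 `CCOC(=O)C1=Cc2ccccc2OC1(OCc1cc(-c2ccc(Cl)cc2)no1)C(F)(F)F` — in this assay compound 2 gives 18200 nM.

Compound 1 stands at the limit of > 150000 nM in this assay, at which 1 of the 2 values shown sits; the assay reports no number for it, only that its inhibition was too weak to measure. For the measured compounds named here, compound 2 is the only compound with a measured number, and no step connecting it to compound 1 is defined, so the two values show no more than that one compound has a number and the other does not.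

Compound 3 `CCOC(=O)C1=Cc2ccccc2OC1(OCc1cn(-c2cccc(C(F)(F)F)c2)nn1)C(F)(F)F` differs from compound 1 by trifluoromethyl in place of hydrogen on an aromatic carbon. With compound 1 sitting at a limit, the size of the step cannot be read from a measured pair; any move from compound 1 to compound 3 in this assay can only be expected to go toward a lower number or to stay at the limit. Compound 3 is therefore estimated at 60000 nM, with a range from 15000 nM to 150000 nM, which means an expected step of an at least 2.5-fold lower number from compound 1 to compound 3 (0.39 log units; beyond the scatter).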

Compound 3, half-maximal inhibitory concentration: > 150000 nM
Compound 3: no number, only a limit; the forecaster's own chance of this, stated with the estimate: 50%; at least 2.5-fold (0.39 log units) between middle value and limit.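

For the compounds shown here, no step from compound 1 to compound 3 can be read, because both compounds give only a limit: the limit of > 150000 nM in this assay, at which 2 of the 3 values shown sit.

The compounds shown leave open how far trifluoromethyl in place of hydrogen on an aromatic carbon shifts inhibition of these cells, if it shifts it at all.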